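Shortening the hydroxamic acid chain from compound 1

The source may hold more compounds than are shown below. What is called first, only, known or untested is meant among the compounds shown, and "the series" means these compounds.

Measured in a functional assay on MDA-MB-231 cells (Homo sapiens) for inhibition, read by MTT assay, with a stated time of 72 h; a lower number here means a stronger inhibitor, a higher number a weaker inhibitor:
- compound 1 (`Nc1nc2cc(-c3nn(CCCCCCCCCC(=O)NO)c4ncnc(N)c34)ccc2o1`): > 50000 nM (a limit, not a number)
- compound 2 (`Nc1ncnc2c1c(-c1cnc3[nH]ccc3c1)nn2CCCCCCC(=O)NO`): 37700 nM

Compound 1 has no number in this assay and stands only at a limit of the assay (the limit of > 50000 nM in this assay, at which 1 of the 2 values shown sits). Compound 3 (`Nc1nc2cc(-c3nn(CCCCCC(=O)NO)c4ncnc(N)c34)ccc2o1`) is the next to be read. The change from compound 1 is hydroxycarbamoyl in place of 4-(hydroxycarbamoyl)butyl on a saturated chain carbon, five bonds along the chain from an aromatic nitrogen. The same difference reads 7-(hydroxycarbamoyl)heptyl to 3-(hydroxycarbamoyl)propyl.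

Going by the values given here, no measured step isolates this change, so any expectation is loose. Among the compounds with values here, the only numerical reading is compound 2 at 37700 nM, and a modest move toward a lower number is expected on that basis, with a continued weak reading in this assay. The estimated change is an at least 2.0-fold lower number from compound 1 to compound 3 (0.30 log units; that floor lies within the scatter). For compound 3 the expected value is 25000 nM, with an estimated range of 6000 nM to 70000 nM.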

Compound 3, half-maximal inhibitory concentration: 19000 nM
For compound 3 the middle estimate is 1.3-fold (0.12 log units) above the measured one; the measured number falls inside the stated range.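

Going from 7-(hydroxycarbamoyl)heptyl to 3-(hydroxycarbamoyl)propyl on the shared core gives an at least 2.6-fold lower number from compound 1 to compound 3 (0.42 log units; beyond the scatter) in this assay and is the first step in the series that isolates the chain at this position. It also gives this core a number, with compound 3 at 19000 nM in this assay where the longer chain gave none. The size of the step is a floor rather than a measured gap, because compound 1 stands only at a limit of the assay: the limit of > 50000 nM in this assay, at which 1 of the 3 values shown sits.

Two chain lengths on one core fix a direction for this pair alone and do not show whether the reading changes steadily with length or turns at an intermediate such as 5-(hydroxycarbamoyl)pentyl, and compound 2 differs from both compounds in more than one place and so cannot fill that gap. Also open, as far as these compounds go, is whether the gain depends on the hydroxamic acid end at all, which a carboxylic acid on the same shortened chain would test, along with whether a still shorter chain such as 2-(hydroxycarbamoyl)ethyl lowers the number further.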